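Methyl on the Imidazole Ring Across Two Carbamate and Lactam Series

The compounds below may be only part of what the source reports. "The series", "measured", "known", "first", "only" and "open" are said of these compounds alone.

The measurements come from a functional assay on the whole organism for antagonist activity, with Mus musculus as the target; a higher number here means that more compound is needed for the effect, a lower number that less compound is needed. Compound 1, `CC1CCC(=O)N1CC#CCn1ccnc1`, gives 20.9 mg/kg in this assay. Compound 2, `Cc1cncn1CC#CCN1C(=O)CCC1C`, gives 14.2 mg/kg in this assay. The two differ by a single change, (methyl in place of hydrogen on an aromatic carbon), and the step is a 1.5-fold lower number from compound 1 to compound 2 (0.17 log units; within the scatter).

Compound 3, `COC(=O)N(C)CC#CCn1ccnc1`, carries a different core. In this assay compound 3 gives only a limit, > 100 mg/kg, and no number. This is the limit of > 100 mg/kg in this assay, at which 1 of the 3 values shown sits. The difference between the core of compound 1 and the core of compound 3 is not broken down here; the two values simply show that compound 1 has a measured dose where compound 3 has a limit.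

Compound 4, `COC(=O)N(C)CC#CCn1cncc1C`, has not yet been measured. It differs from compound 3 by methyl in place of hydrogen on an aromatic carbon, the same change, at the same place, that leads from compound 1 to compound 2. Going by the values given here, since the only measured instance of this change is the step of a 1.5-fold lower number from compound 1 to compound 2 (0.17 log units; within the scatter), the step that the limit leaves unreadable from compound 3 to compound 4 is expected to be of a similar small size. As compound 3 itself sits at a limit, compound 4 is expected to give roughly 130 mg/kg in this assay, most likely between 50 mg/kg and 400 mg/kg, and there is a considerable chance that the assay again reports only a limit for compound 4.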

Compound 4, dose for half-maximal effect: > 100 mg/kg
Compound 4 ended at the assay's limit; the forecaster's own chance of this, stated with the estimate: 70%; the middle value does not contradict the limit.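

In this assay compound 4 gives > 100 mg/kg, which is a limit of the assay and not a number. Compound 3 stands at a limit as well, so no step between compound 3 and compound 4 can be read: the limit of > 100 mg/kg in this assay, at which 2 of the 4 values shown sit.

The compounds shown leave open whether methyl in place of hydrogen on an aromatic carbon changes the dose needed with the core of compound 3.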